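Swapping a thiophene for a larger thioether at the acetal carbon

A few compounds are considered here, and "the series" means these few. Any claim that something is new, unique, unknown or untested is made for them only; others in the source may bear on it.

Measured compounds:
compound 1 `O=C(O)CC/C=C\CC1COC(c2ccsc2)OC1c1cccnc1`, 1580 nM
compound 2 `O=C(O)CC/C=C\CC1COC(c2cccs2)OC1c1cccnc1`, 1000 nM
compound 3 `CC(C)(Oc1ccccc1F)C1OCC(C/C=C\CCC(=O)O)C(c2cccnc2)O1`, 166 nM

In a functional assay for inhibition, with Homo sapiens as the target (on this read-out lower numbers stand for tighter binding and higher numbers for weaker binding), compound 2 gives 1000 nM, the second highest of the three numbers. Among the measured compounds shown here, its nearest neighbour is compound 1, whose number is higher only within the scatter, and the only single-point step on record is a 1.6-fold lower number from compound 1 to compound 2 (0.20 log units; within the scatter), a change at the same saturated ring carbon that made no real difference. Compound 3 carries a bulkier group at that carbon and gives 166 nM, well beyond the scatter from compound 2.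

Compound 4 `CC(C)(Sc1ccccc1)C1OCC(C/C=C\CCC(=O)O)C(c2cccnc2)O1` is the next compound. Relative to compound 2 the change is a group of 10 heavy atoms (9 carbon, 1 sulfur; one six-membered aromatic ring of carbon only) in place of a group of 5 heavy atoms (4 carbon, 1 sulfur; one five-membered aromatic ring with 1 hetero atom), on a saturated ring carbon. For the measured compounds named here, no measured step covers this exact exchange, but the larger group in compound 3 went with a clearly lower number, and the thiophene swap in the step from compound 1 to compound 2 was flat. A lower number for compound 4 is therefore expected, roughly by a 4.0-fold lower number from compound 2 to compound 4 (0.60 log units; beyond the scatter), with uncertainty because compound 3 also carries a fluorine and an oxygen linker that compound 4 lacks. In this assay compound 4 is estimated at 250 nM, within a range of 80 nM to 800 nM.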

Compound 4, dissociation constant: 200 nM
Compound 4: middle estimate off by 1.3-fold (0.10 log units), on the high side; the measured number falls inside the stated range.
By their numbers in this assay, from the lowest: compounds 3 and 4 (each within the scatter of the next); then compounds 2 and 1 (each within the scatter of the next).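

In this assay the larger group on the saturated ring carbon between two ring oxygen atoms now has direct steps, a 5.0-fold lower number from compound 2 to compound 4 (0.70 log units; beyond the scatter) and a 7.9-fold lower number from compound 1 to compound 4 (0.90 log units; beyond the scatter), so the gain appears against either thiophene. Changing only the linked ring gives a 1.2-fold higher number from compound 3 to compound 4 (0.08 log units; within the scatter), so phenylsulfanyl and 2-fluorophenoxy on the saturated chain carbon are not told apart here, and the low number does not depend on the fluorine or the oxygen linker. No supporting measurement bears on why these numbers move.

Still open, from the compounds shown here alone, is whether the phenyl ring or the methyl groups on the chain carbon account for the lower numbers. Also open, going by these compounds, is how an amine link in place of the sulfur, or a plain phenyl directly on the ring carbon, would read out.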